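Chloro to methoxy on a pair of inactive carbamothioates

A few compounds are considered here, and "the series" means these few. Any claim that something is new, unique, unknown or untested is made for them only; others in the source may bear on it.

Compound 1 `COc1ccccc1NC(=O)SC[C@H](NC(C)=O)C(=O)O`. In a functional assay on OVCAR-3 cells (Homo sapiens) for cytotoxicity, read by MTT assay, with a stated time of 6 days (a lower number here means a stronger inhibitor, a higher number a weaker inhibitor), compound 1 gives > 200000 nM, which is a limit of the assay and not a number.
Compound 2 `CC(=O)N[C@@H](CSC(=O)Nc1ccc(Cl)cc1)C(=O)O`. In this assay compound 2 gives > 200000 nM, likewise a limit of the assay and not a number.

Compound 2 therefore stands at the limit, not at a measured number, and the two values shown both sit there, as stated by the limit of > 200000 nM in this assay, at which 2 of the 2 values shown sit. Nothing on the numbers shown separates compound 2 from compound 1 in either direction.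

Compound 3 `COc1ccc(NC(=O)SC[C@H](NC(C)=O)C(=O)O)cc1` has not yet been measured in this assay. It differs from compound 2 by methoxy in place of chloro on an aromatic carbon. Among the measured compounds shown here, no step between measured compounds exists here, so the size of the change in this assay cannot be read from the data and can only be expected. Compound 1, which also carries a methoxy and reaches only > 200000 nM, offers no sign that a methoxy in place of chloro brings the value into the measurable range. The expected step is a step that the limit leaves unreadable from compound 2 to compound 3, that is, none beyond the scatter, with the reading most likely remaining a limit. For compound 3 the estimate in this assay is 300000 nM, within a range from 100000 nM to 1000000 nM.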

Compound 3, half-maximal inhibitory concentration: > 200000 nM
Compound 3 gave a limit, no number; the forecaster's own chance of this, stated with the estimate: 85%; the middle value lies beyond the limit too.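

No step can be read between compound 2 and compound 3 in this assay, since each gives a limit of the assay and not a number: the limit of > 200000 nM in this assay, at which 3 of the 3 values shown sit.

The compounds shown leave open whether methoxy in place of chloro on an aromatic carbon changes the reading at all, and whether any close relative of these compounds reaches a measurable value in this assay.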